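The source may report more compounds than this note shows. Statements on the series, on what has been measured and on what is new or still open speak of the compounds shown alone.

Compound 1 `CCCc1nc(-c2cnc3ccc(-c4ccc(N)cc4)cc3c2)no1` in a functional assay on RD cells (Homo sapiens) for inhibition, read by luminescence and ATP content, with a stated time of 72 h (on this read-out lower numbers stand for higher toxicity in this test and higher numbers for lower toxicity in this test), gives > 800 nM, which is a limit of this assay. Compound 2 `CC(C)(C)c1nc(-c2cnc3ccc(-c4ccc(N)cc4)cc3c2)no1` gives > 7400 nM, also a limit. Compound 3 `Cc1ccc(-c2ccc3ncc(-c4noc(C(F)(F)F)n4)cc3c2)cc1` gives > 22200 nM, again a limit.

All three values shown are therefore limits and none is a number. Compound 3 stands at the limit of > 22200 nM in this assay, at which 1 of the 3 values shown sits, the highest concentration reached among the three. Among the measured compounds shown here, the only step between measured compounds that differ in one place is a step that the two limits leave unreadable from compound 1 to compound 2, which concerns the substituent on the shared core's five-membered ring rather than the six-membered carbon ring at the other end.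

The change from compound 3 to compound 4 `CN(C)c1ccc(-c2ccc3ncc(-c4noc(C(F)(F)F)n4)cc3c2)cc1` is dimethylamino in place of methyl on an aromatic carbon. For the measured compounds named here, no measured step bears on this change, since the one step known lies at another place and is itself unreadable. What the data show is only that nothing among the three compounds has reached a measurable toxicity in this assay.

Compound 4 is expected to give 30000 nM, with a range from 8000 nM to 100000 nM, most probably again reported as a limit. The expected step is a step that the limit leaves unreadable from compound 3 to compound 4, none beyond the scatter.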

Compound 4, half-maximal cytotoxic concentration: > 22200 nM
Compound 4 gave a limit, no number; the forecaster's own chance of this, stated with the estimate: 80%; the middle value is on the limit's open side.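

Among the compounds shown here, compound 4 gives > 22200 nM in this assay, which is a limit and not a number; compound 3 also stands at a limit, so no step between compound 3 and compound 4 can be read. The compounds shown leave open at what concentration any of them becomes toxic in this assay.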